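Amide replacement on the core of compound 1

The source may report more compounds than this note shows. Statements on the series, on what has been measured and on what is new or still open speak of the compounds shown alone.

Compound 1 `COc1ccc2c(c1)OC(c1cc(OC)c(OC)c(OC)c1)C(C(=O)NC(C)(C)C)=C2` gives 28400 nM in a functional assay for inhibition of nuclear factor NF-kappa-B complex (Homo sapiens) (a lower number here means a stronger inhibitor, a higher number a weaker inhibitor), the higher of the two plain numbers in this set. Compound 3 `COc1ccc2c(c1)OC(c1cc(OC)c(OC)c(OC)c1)C(C(=O)N(C)OC)=C2` gives 11700 nM, and a 2.4-fold lower number from compound 1 to compound 3 (0.39 log units; beyond the scatter). Compound 2 `COc1ccc2c(c1)OC(c1cc(OC)c(OC)c(OC)c1)C(C(=O)N1CCCCC1)=C2` returns only a limit, > 50000 nM. Against that limit, an at least 1.7-fold higher number from compound 1 to compound 2 (0.24 log units; that floor lies within the scatter). Compound 4 `COc1ccc2c(c1)OC(c1cc(OC)c(OC)c(OC)c1)C(C=O)=C2` carries hydrogen in place of (tert-butyl)amino on a carbonyl carbon. The measured steps all exchange one amine on the carbonyl carbon for another, and none of them moved the number more than modestly; none removes the amide nitrogen altogether, so they bear on compound 4 only loosely. For compound 4 a step of a 1.1-fold higher number from compound 1 to compound 4 (0.05 log units; within the scatter) is expected, toward a somewhat higher number if any, with a real chance that the read-out is again a limit. Compound 4 is estimated at 32000 nM, between 9000 nM and 100000 nM.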

Compound 4, half-maximal inhibitory concentration: 13500 nM
Beside the measured number, compound 4's estimate is 2.4-fold (0.37 log units) above it; low and high end bracket the measured number.
By their numbers in this assay, from the lowest: compounds 3 and 4 (each within the scatter of the next); then compound 1. At a limit, above all of these: compound 2.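

Losing the amine altogether at this carbonyl carbon, leaving a formyl group, does not cost activity (a 2.1-fold lower number from compound 1 to compound 4 (0.32 log units; beyond the scatter)), so within this set the amide nitrogen is not required. Compound 4 cannot be told apart from the Weinreb-type compound 3 (a 1.2-fold higher number from compound 3 to compound 4 (0.06 log units; within the scatter)). The value of compound 2 is a limit, so the remaining step is only a floor (an at least 3.7-fold lower number from compound 2 to compound 4 (0.56 log units; beyond the scatter)).

Going by these compounds, what a carboxylic acid or a hydroxymethyl group would give at this position stays open. So does whether any group here reaches much lower numbers than compounds 3 and 4.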